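Chloro added next to the trifluoromethyl on the urea aryl

A few compounds are considered here, and "the series" means these few. Any claim that something is new, unique, unknown or untested is made for them only; others in the source may bear on it.

Among the compounds with values here, compound 2 `COc1cc(-c2nn(-c3cccc(NC(=O)Nc4cccc(C(F)(F)F)c4)c3)cc2-c2ccncc2)ccc1Cl` is the weaker of the two measured compounds in a functional assay on MDA-MB-468 cells (Homo sapiens) for inhibition, read by sulforhodamine B assay, with a stated time of 48 h (on this read-out higher numbers stand for weaker inhibition of growth and lower numbers for stronger inhibition of growth), where compound 2 gives 598 nM; the only neighbour is compound 1 `COc1cc(-c2nn(-c3cccc(NC(=O)Nc4cc(C(F)(F)F)cc(C(F)(F)F)c4)c3)cc2-c2ccncc2)ccc1Cl`, which gives 307 nM in this assay, a gap that stays within the scatter. Compound 3 `COc1cc(-c2nn(-c3cccc(NC(=O)Nc4ccc(Cl)c(C(F)(F)F)c4)c3)cc2-c2ccncc2)ccc1Cl` differs from compound 2 by chloro in place of hydrogen on an aromatic carbon, ortho to a trifluoromethyl group and para to a large group. Within the data shown here, the one measured step that bears on this change is the removal of a trifluoromethyl from the same ring, a 1.9-fold higher number from compound 1 to compound 2 (0.29 log units; within the scatter), which shows that adding or taking away a substituent on this ring moved the number only modestly. A chloro is a smaller group than a trifluoromethyl, so no step beyond the scatter is expected from compound 2 to compound 3 in this assay, with a slight lean to a lower number, a 1.5-fold lower number from compound 2 to compound 3 (0.17 log units; within the scatter). Compound 3 is therefore estimated at 400 nM, within a range from 150 nM to 1000 nM.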

Compound 3, concentration for 50% growth inhibition: 833 nM
Compound 3: the middle estimate sits 2.1-fold (0.32 log units) below what was measured; measured number inside the range.
By their numbers in this assay, from the lowest: compounds 1, 2 and 3 (each within the scatter of the next, the first and the last beyond it).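

Chloro in place of hydrogen on an aromatic carbon, ortho to a trifluoromethyl group and para to a large group, gives a 1.4-fold higher number from compound 2 to compound 3 (0.14 log units; within the scatter) in this assay and so leaves the number within the scatter. This position therefore accepts a chloro with no step beyond the scatter, at least on a ring that keeps its trifluoromethyl group. With a 1.9-fold higher number from compound 1 to compound 2 (0.29 log units; within the scatter) as the earlier change on this ring, two single changes on the urea aryl have now been read, and both stay within the scatter, so neither compound 2 nor compound 3 marks this ring as sensitive to the substitutions shown, and nothing available accounts for the result or tells what the chloro does here.

From the compounds shown here alone, it remains open whether a different group at this same position, such as a methoxy, an amine or a carboxylic acid, would produce a step beyond the scatter in this assay or would also stay within it. Going by these compounds, it is also open whether chloro at this position would read the same with the trifluoromethyl group replaced by hydrogen, since in compound 3 the two groups occur together.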